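This account rests on a few compounds, and the source may have more. Where it says the series, first, only, none or still open, it means among the compounds named here.

Measured compounds:
- compound 1, `COc1ccc(/C=C/C(=O)c2ccc(OC)c3c2OC(C)(C)C=C3)c(F)c1`: 4880 nM
- compound 2, `COc1ccc(C(=O)/C=C/c2ccc3ccccc3n2)c2c1C=CC(C)(C)O2`: 2350 nM
- compound 3, `COc1ccc(C(=O)/C=C/c2cccc3ccccc23)c2c1C=CC(C)(C)O2`: > 10000 nM

Of the compounds shown here, three sharing the same core have been tested in a functional assay on SK-OV-3 cells (Homo sapiens) for antiproliferative activity, read by MTT assay, with a stated time of 24 h; a lower number here means a stronger inhibitor, a higher number a weaker inhibitor. Compound 1 `COc1ccc(/C=C/C(=O)c2ccc(OC)c3c2OC(C)(C)C=C3)c(F)c1` gives 4880 nM in this assay, which is the higher of the two numbers reported, and its distance from compound 2 lies beyond the scatter. Compound 2 `COc1ccc(C(=O)/C=C/c2ccc3ccccc3n2)c2c1C=CC(C)(C)O2` gives 2350 nM in this assay. For compound 3 `COc1ccc(C(=O)/C=C/c2cccc3ccccc23)c2c1C=CC(C)(C)O2`, this assay reports only a limit, > 10000 nM, and not a number; this is the limit noted as the limit of > 10000 nM in this assay, at which 1 of the 3 values shown sits.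

The piece follows the step from compound 1 to compound 4 `COc1ccc(C(=O)/C=C/c2ccccc2Cl)c2c1C=CC(C)(C)O2`, which has not yet been measured in this assay. The structural change is 2-chlorophenyl in place of 2-fluoro-4-methoxyphenyl on a double-bonded chain carbon bound to a double-bonded chain carbon. Among the compounds with values here, no single-change step between measured compounds is available to anchor the size of this change. The change removes the one hydrogen-bond acceptor of the leaving group and exchanges fluorine for chlorine, while the rest of compound 1 is kept.

In this assay the step from compound 1 to compound 4 is expected to be small, most likely none beyond the scatter, with a modest lean toward a higher number; the expected step is a 1.1-fold higher number from compound 1 to compound 4 (0.05 log units; within the scatter). Compound 4 is estimated at 5500 nM, within a range from 2000 nM to 15000 nM.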

Compound 4, half-maximal inhibitory concentration: > 10000 nM
Compound 4: only a limit was reported; the forecaster's own chance of this, stated with the estimate: 25%; middle value at least 1.8-fold (0.25 log units) away from the limit.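

The step of an at least 2.0-fold higher number from compound 1 to compound 4 (0.31 log units; beyond the scatter) in this assay is the first single-change step among the compounds shown, and it lies beyond the scatter, so the group on a double-bonded chain carbon bound to a double-bonded chain carbon can matter in this assay. For compound 4, the assay gives only a limit, > 10000 nM, so the step sets a minimum and not a full size. Compound 3 is no longer the only compound at this limit: the limit of > 10000 nM in this assay, at which 2 of the 4 values shown sit.

The compounds shown leave open whether the step comes from the loss of the methoxy group or from the exchange of fluorine for chlorine, since 2-chlorophenyl in place of 2-fluoro-4-methoxyphenyl changes both at once. On these data alone, a 2-fluorophenyl or a 2-chloro-4-methoxyphenyl group at this place would separate the two, and how an amine on the same aromatic ring would read in this assay also remains open.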